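A Fluorophenyl Swap at Low Growth Inhibition

This account rests on a few compounds, and the source may have more. Where it says the series, first, only, none or still open, it means among the compounds named here.

In a functional assay on MIA PaCa-2 cells (Homo sapiens) for inhibition, read by MTT assay, with a stated time of 48 h, tested at 10 uM (on this read-out lower numbers stand for less inhibition of growth and higher numbers for more inhibition of growth at the one concentration tested), compound 1 (`Cc1cc(=O)c2c(O)c(CN(C(C)C)C(C)C)c(O)c([C@H]3CCN(C)C[C@H]3O)c2o1`) gives 11% and compound 2 (`Cc1cc(=O)c2c(O)c(CN3CCCC3C(=O)O)c(O)c([C@H]3CCN(C)C[C@H]3O)c2o1`) gives 10%. Compound 3 (`Cc1oc2c([C@H]3CCN(C)C[C@H]3O)c(O)cc(O)c2c(=O)c1C(O)c1c(Cl)cccc1Cl`) gives 0%, a value within the scatter of compound 2 and beyond it from compound 1. Compound 4 (`Cc1oc2c([C@H]3CCN(C)C[C@H]3O)c(O)cc(O)c2c(=O)c1C(O)c1ccc(F)cc1`) differs from compound 3 as follows: 4-fluorophenyl in place of 2,6-dichlorophenyl on a saturated chain carbon bound to an aromatic carbon and an oxygen on a saturated carbon. This places 4-fluorophenyl in place of 2,6-dichlorophenyl on a saturated chain carbon bound to an aromatic carbon and an oxygen on a saturated carbon. Among the measured compounds shown here, no measured step covers this change. The only one, a number 1 percentage points lower from compound 1 to compound 2 (within the scatter), exchanges a different group and offers indirect guidance at best. A small step within the scatter is therefore expected in this assay: a number 8 percentage points higher from compound 3 to compound 4 (within the scatter). Compound 4 is estimated at 8%, with an expected range of 0% to 22%.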

Compound 4, percent growth inhibition at one concentration: 17%
The estimate for compound 4 lay 9 percentage points below the measured number, and the stated range covers the measured number.
By their numbers in this assay, from the lowest: compounds 3, 2, 1 and 4 (each within the scatter of the next, the first and the last beyond it).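

In this assay, the change from (2,6-dichlorophenyl)(hydroxy)methyl to (4-fluorophenyl)(hydroxy)methyl gives a number 17 percentage points higher from compound 3 to compound 4 (beyond the scatter) and is the only step shown that lies beyond the scatter. The aryl group on this saturated chain carbon can therefore move the read-out, whereas the amine exchange at the other shown side chain gave a number 1 percentage points lower from compound 1 to compound 2 (within the scatter) and did not. Nothing available explains this step.

The step removes both chlorines and adds the fluorine at once, and the compounds shown do not separate these two changes. Also open, as far as these compounds go, is how an unsubstituted phenyl or a 4-chlorophenyl would read on this carbon.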